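Extending the ethoxy group of compound 3

The compounds below may be only part of what the source reports. "The series", "measured", "known", "first", "only" and "open" are said of these compounds alone.

Compound 1 `Cc1noc(CC2OC(=O)c3ccccc32)n1`: > 40000 nM
Compound 2 `O=C1OC(Cc2nc(Cc3ccccc3)no2)c2ccccc21`: > 40000 nM
Compound 3 `CCOc1ccc(C(O)C2OC(=O)c3c(OC)cc(OC)cc32)cc1`: > 40000 nM

All three entries come from an ADME assay on RAW264.7 cells (Mus musculus) for cytotoxicity, read by MTT assay, with a stated time of 24 h, in the absence of a further agent (a lower number here means a stronger inhibitor, a higher number a weaker inhibitor), and each is a limit rather than a number. The series therefore offers only (the limit of > 40000 nM in this assay, at which 3 of the 3 values shown sit). Compound 3 stands at > 40000 nM, which is a limit, so its true position is not known.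

Compound 4 `COCCCOc1ccc(C(O)C2OC(=O)c3c(OC)cc(OC)cc32)cc1` is the next compound to be measured. It differs from compound 3 by methoxymethyl in place of hydrogen on a saturated chain carbon, two bonds along the chain from an oxygen on an aromatic ring. Read one bond further out, the same difference turns ethoxy into 3-methoxypropoxy.

Among the compounds with values here, the only measured step is a step that the two limits leave unreadable from compound 1 to compound 2. It is a different change, and it offers no size to carry over to this one. Within the data shown here, no measured step therefore points to a shift in either direction, and no step beyond the usual scatter is expected. Compound 4 is expected to remain at the limit, with a number reported only occasionally. The expected step is a step that the limit leaves unreadable from compound 3 to compound 4. Compound 4 is estimated at 50000 nM, with an expected range of 20000 nM to 100000 nM.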

Compound 4, half-maximal inhibitory concentration: > 40000 nM
Compound 4 was reported as a limit (the forecaster's own chance of this, stated with the estimate: 85%); the middle value lies beyond the limit too.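

In this assay compound 4 gives > 40000 nM, which is a limit. Within the data shown here, compound 3 is also reported as a limit, so no step from compound 3 to compound 4 can be read. The compounds shown leave open whether any change among them alters the true value, as every result remains a limit: the limit of > 40000 nM in this assay, at which 4 of the 4 values shown sit.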